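Ethoxycarbonyl to carboxy: the step to compound 4

The source may hold more compounds than are shown below. What is called first, only, known or untested is meant among the compounds shown, and "the series" means these compounds.

- compound 1 `CCOC(=O)/C(O)=C/C(=O)c1cn(Cc2ccc(F)cc2)c2ccc(OC)c(OC)c12` gives 111000 nM
- compound 2 `COc1cc(OC)c2c(c1)c(C(=O)/C=C(\O)C(=O)O)cn2Cc1ccc(F)cc1` gives 58500 nM
- compound 3 `CCOC(=O)/C(O)=C/C(=O)c1cn(Cc2ccc(F)cc2)c2c(OC)c(OC)ccc12` gives 119000 nM

All three compounds were measured in an ADME assay on MT4 cells (Homo sapiens) for cytotoxicity, read by MTT assay; on this read-out lower numbers stand for higher toxicity in this test and higher numbers for lower toxicity in this test. Compound 1 stands second highest of the three numbers, but compound 3 and compound 2 each lie within the usual scatter of it, so its place in that order carries little weight.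

Compound 4 `COc1ccc2c(c(C(=O)/C=C(\O)C(=O)O)cn2Cc2ccc(F)cc2)c1OC` has not yet been measured. It derives from compound 1 by hydrogen in place of ethyl on an oxygen next to a carbonyl group, which reads as ethoxycarbonyl to carboxy. Among the measured compounds shown here, no pair of measured compounds isolates this change, so the data offer no direct guide. For the measured compounds named here, the only measured compound carrying carboxy is compound 2 (58500 nM) , whose value stays within the scatter of that of compound 1. In this assay no step beyond the scatter is therefore expected, with any drift expected towards a lower number. The expected step is a 1.6-fold lower number from compound 1 to compound 4 (0.20 log units; within the scatter). For compound 4 the estimated value is 70000 nM, with an expected range from 30000 nM to 150000 nM.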

Compound 4, half-maximal cytotoxic concentration: 126000 nM
Compound 4: middle estimate off by 1.8-fold (0.26 log units), on the low side; measured number inside the range.
By their numbers in this assay, from the lowest: compounds 2, 1, 3 and 4 (each within the scatter of the next, the first and the last beyond it).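

Among the compounds shown here, with compound 4 the set gains its first pair of compounds that differ in one place, and so the first direct reading of this change: in this assay, going from ethoxycarbonyl to carboxy, with hydrogen in place of ethyl on an oxygen next to a carbonyl group, gives a 1.1-fold higher number from compound 1 to compound 4 (0.06 log units; within the scatter). For the compounds shown here, on the core of compound 1, the ethyl group on this oxygen can therefore be exchanged for hydrogen without a step beyond the scatter in this cytotoxicity read-out, which the earlier compounds, none of them a one-place pair, could not show. Nothing measured here speaks to why the read-out stays within the scatter across this change.

The compounds shown leave open whether a longer chain such as butyl on this oxygen, or an amine-bearing chain such as 2-aminoethyl, would also stay within the scatter of compound 1. They also leave open whether the same exchange of ethyl for hydrogen would give a similar step on the core of compound 3, where the methoxy groups are placed differently.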